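Extending the sulfonyl substituent to a linked pair of thiophene rings

A few compounds are considered here, and "the series" means these few. Any claim that something is new, unique, unknown or untested is made for them only; others in the source may bear on it.

Of the compounds shown here, two sharing one core have been tested in a functional assay on HepG2 cells for inhibition of squalene monooxygenase (Homo sapiens); on this read-out higher numbers stand for weaker inhibition and lower numbers for stronger inhibition. Compound 1 `CCN(C/C=C/C#CC(C)(C)C)Cc1cccc(OCCN(C)S(=O)(=O)c2ccsc2)c1` gives 250 nM. Compound 2 `CCN(C/C=C/C#CC(C)(C)C)Cc1cccc(OCCN(C)S(=O)(=O)Cc2cccs2)c1` gives 200 nM. Among the compounds with values here, compound 2 carries the lowest of the two numbers, but its only neighbour is compound 1, and the two values lie within the scatter of each other, so no order between them can be read. Within the data shown here, the one step measured so far, a 1.3-fold lower number from compound 1 to compound 2 (0.10 log units; within the scatter), changed what sits on the sulfonyl sulfur and moved the number only within the scatter.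

Compound 3 `CCN(C/C=C/C#CC(C)(C)C)Cc1cccc(OCCN(C)S(=O)(=O)c2ccc(-c3cccs3)s2)c1` is not yet measured. It differs from compound 2 in the same place: 5-(thiophen-2-yl)thiophen-2-yl in place of (thiophen-2-yl)methyl on a sulfonyl sulfur. The earlier swap on the sulfonyl sulfur bears on this step, since it too exchanged the group there, but it was small and swapped two groups of similar size, whereas this step enters a larger group. Among the measured compounds shown here, with no measured step of that kind, the expectation rests mainly on the small earlier change, and a step of no change at the digits printed from compound 2 to compound 3 (within the scatter) is estimated, that is, none clearly beyond the scatter. Compound 3 is therefore expected to give about 200 nM, with a range from 70 nM to 600 nM.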

Compound 3, half-maximal inhibitory concentration: 10000 nM
Compound 3: the middle estimate sits 50-fold (1.70 log units) below what was measured; measured number outside the range, above it.
By their numbers in this assay, from the lowest: compounds 2 and 1 (each within the scatter of the next); then compound 3.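

In this assay, entering 5-(thiophen-2-yl)thiophen-2-yl on the sulfonyl sulfur gives a 50-fold higher number from compound 2 to compound 3 (1.70 log units; beyond the scatter) and also a 40-fold higher number from compound 1 to compound 3 (1.60 log units; beyond the scatter) when compared with the thiophen-3-yl group. The position therefore does not accept every thiophene-bearing group alike: the two groups with one five-membered aromatic ring stay within the scatter of each other, while the group with two such rings stands far higher on this read-out, meaning much weaker inhibition. None of the available data speaks to why this group costs so much, so the finding stands only as a comparison among these three compounds.

The compounds shown leave open whether the large rise follows the second thiophene ring itself or would also appear with another group on the first thiophene ring, such as a phenyl ring, a pyridine ring or a methyl group. They also leave open where the change from a small to a poor substituent sets in, which a single benzyl group or a longer alkyl chain on the sulfonyl sulfur could help to show.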